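The compounds below may be only part of what the source reports. "The series", "measured", "known", "first", "only" and "open" are said of these compounds alone.

Going by the values given here, in a physicochemical assay for lipophilicity, read by LC-MS, in phosphate buffer, measured as octanol-water partition, with a stated time of 30 min, at pH 7.4, tested at 200 mM (on this read-out lower numbers stand for lower lipophilicity and higher numbers for higher lipophilicity), compound 1 (`Cn1c(COc2cccc(C(=O)O)c2)nc2ccc(Oc3ccc(F)cc3)nc21`) gives 1.5 and compound 2 (`Cc1cc(C)cc(Oc2ccc3nc(COc4cccc(C(=O)O)c4)n(C)c3n2)c1`) gives 2.3 as the higher of the two numbers so far. Among the compounds with values here, the one measured step (a number 0.80 log units higher from compound 1 to compound 2 (beyond the scatter)) came with 3,5-dimethylphenyl in place of 4-fluorophenyl on an oxygen on an aromatic ring. Compound 3 (`Cc1ccc(Oc2ccc3nc(COc4cccc(C(=O)O)c4)n(C)c3n2)cc1C`) has yet to be measured in this assay and differs from compound 2 as follows (3,4-dimethylphenyl in place of 3,5-dimethylphenyl on an oxygen on an aromatic ring), with 3,4-dimethylphenyl in place of 3,5-dimethylphenyl on an oxygen on an aromatic ring and the same atoms joined differently. The measured step exchanged one group for a different set of atoms and this one does not, so its size is only a loose guide, and compound 2 at 2.3 serves as the anchor. No shift beyond the scatter is expected, and the estimated step (no change at the digits printed from compound 2 to compound 3 (within the scatter)) reflects that. Compound 3 is expected at 2.3 within an estimated range from 1.9 to 2.7 when measured.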

Compound 3, distribution coefficient: 2.2
Compound 3: middle estimate off by 0.10 log units, on the high side, within the range that was stated.
By their numbers in this assay, from the lowest: compound 1; then compounds 3 and 2 (each within the scatter of the next).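

In this assay, the exchange at this position gives a number 0.10 log units lower from compound 2 to compound 3 (within the scatter), so the read-out does not separate 3,5-dimethylphenyl from 3,4-dimethylphenyl on the oxygen. The exchange of 4-fluorophenyl for 3,4-dimethylphenyl gives a number 0.70 log units higher from compound 1 to compound 3 (beyond the scatter), so the gap from compound 1 seen earlier with one dimethylphenyl group also appears with the other, and among these three compounds it goes with the choice of group and not with one particular arrangement of the two methyl groups. Nothing here offers an explanation for either step.

From the compounds shown here alone, whether a single methyl group, as in 4-methylphenyl, would stand with compound 1 or with compounds 2 and 3 remains open. So does the reading for a non-aromatic group such as cyclohexyl on the same oxygen, or for an amine on the phenyl ring.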